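Thiazolyl for thienyl on the shared core: compound 3

The source may hold more compounds than are shown below. What is called first, only, known or untested is meant among the compounds shown, and "the series" means these compounds.

Measured compounds:
compound 1 `CCn1nc(-c2ccccn2)c2sccc2c1=O`, 782 nM
compound 2 `CCn1nc(-c2cccs2)c2sccc2c1=O`, 724 nM

In an assay on CHO cells for displacement of a labelled ligand from adenosine receptor A1 (Homo sapiens), read by scintillation counting, with a stated time of 90 min (on this read-out higher numbers stand for weaker inhibition and lower numbers for stronger inhibition), compound 1 gives 782 nM and compound 2 gives 724 nM; the two values sit within the scatter of each other, so neither compound is set apart. Within the data shown here, the only step measured so far, a 1.1-fold lower number from compound 1 to compound 2 (0.03 log units; within the scatter), exchanged the aryl group on the shared core and left the number essentially where it was.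

Compound 3 `CCn1nc(-c2nccs2)c2sccc2c1=O` differs from compound 2 by 1,3-thiazol-2-yl in place of thiophen-2-yl on an aromatic carbon. Among the measured compounds shown here, the step that bears on it is a 1.1-fold lower number from compound 1 to compound 2 (0.03 log units; within the scatter), the one earlier exchange at this same position, and that step stayed within the scatter. On this basis no step beyond the scatter is expected in this assay, and the change from compound 2 to compound 3 is estimated at a 1.0-fold lower number from compound 2 to compound 3 (0.01 log units; within the scatter). For compound 3 the expected value in this assay is 700 nM, with a range from 300 nM to 1800 nM.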

Compound 3, inhibition constant: 113 nM
Beside the measured number, compound 3's estimate is 6.2-fold (0.79 log units) above it, outside the stated range (below it).
By their numbers in this assay, from the lowest: compound 3; then compounds 2 and 1 (each within the scatter of the next).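

In this assay, the aromatic carbon of the shared core that carries these rings proves sensitive to the group placed on it: 1,3-thiazol-2-yl brings a 6.4-fold lower number from compound 2 to compound 3 (0.81 log units; beyond the scatter) and also a 6.9-fold lower number from compound 1 to compound 3 (0.84 log units; beyond the scatter), whereas thiophen-2-yl and pyridin-2-yl could not be told apart. The leaving and entering five-membered rings have the same count of heavy atoms, and the entering ring carries 2 hetero atoms where thiophen-2-yl carries 1, so a small exchange within the ring is enough for a step beyond the scatter. Nothing available on these compounds accounts for the step.

Open, on these data alone, is whether the step extends to other rings with two hetero atoms, such as oxazol-2-yl or imidazol-2-yl. Also open, as far as these compounds go, is how this position responds to a non-aromatic group such as an amine, and how the step holds when the ethyl group gives way to a longer chain.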